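The source may report more compounds than this note shows. Statements on the series, on what has been measured and on what is new or still open speak of the compounds shown alone.

Working notes on the series. Compound 1 `C/C(=N\Cc1ccccc1)c1c(O)c2ccccc2[nH]c1=O` is read in an assay on isolated protein for inhibition of myosin-2 (Bos taurus), read by spectrophotometry, with a stated time of 24 min; a lower number here means a stronger inhibitor, a higher number a weaker inhibitor. In that assay compound 1 gives >= 100000 nM, which is a limit of the assay rather than a number. Compound 2 `C/C(=N\C(C)C)c1c(O)c2ccccc2[nH]c1=O` gives >= 100000 nM, again a limit. Compound 3 `C/C(=N\CC(C)C)c1c(O)c2ccccc2[nH]c1=O` gives >= 100000 nM, also a limit. The step that the two limits leave unreadable from compound 1 to compound 2, the step that the two limits leave unreadable from compound 1 to compound 3 and the step that the two limits leave unreadable from compound 2 to compound 3 all remain unreadable, as shown by the limit of >= 100000 nM in this assay, at which 3 of the 3 values shown sit. Where compound 1 stands can thus be said only in that it sits at the limit of this assay together with the other two.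

Compound 4 `C/C(=N\Cc1ccccc1)c1c(O)c2ccccc2n(C)c1=O` differs from compound 1 by methyl in place of hydrogen on an aromatic nitrogen. For the measured compounds named here, none of the measured steps touches this position; all three concern the group on the double-bonded nitrogen, and none of them yields a readable size. Going by the values given here, no measured step therefore bears directly on the change to compound 4, and no direction can be taken from the set. Compound 4 is expected to stay at the limit, with an estimated value of 100000 nM and a range from 30000 nM to 300000 nM. The step of a number no higher from compound 1 to compound 4 (the limit leaves the size open) is expected to be none beyond the scatter.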

Compound 4, half-maximal inhibitory concentration: >= 100000 nM
Compound 4: no number, only a limit; the forecaster's own chance of this, stated with the estimate: 80%; the middle value lies on the limit itself.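

No new step can be read between compound 1 and compound 4, as both stand only at a limit and not at a number: the limit of >= 100000 nM in this assay, at which 4 of the 4 values shown sit.

The compounds shown leave open whether any change to the group on the double-bonded nitrogen or on the aromatic nitrogen gives a readable inhibition in this assay.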